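Shortening the acid chain of compound 2

This account rests on a few compounds, and the source may have more. Where it says the series, first, only, none or still open, it means among the compounds named here.

Measured in a functional assay (plasma) for inhibition, with Homo sapiens as the target; a higher number here means a weaker inhibitor, a lower number a stronger inhibitor
Compound 1 `Cc1ccc(S(=O)(=O)N[C@H]2CC[C@H](O)[C@@H]2C/C=C\CCC(=O)O)cc1` gives 2500 nM
Compound 2 `O=C(O)CCC/C=C\C[C@@H]1[C@@H](NS(=O)(=O)c2ccc(Cl)cc2)CC[C@@H]1O` gives 190 nM

Compound 2 stands at 190 nM as the lower of the two numbers, with compound 1 beyond the scatter from it. Compound 3 `O=C(O)CC/C=C\C[C@@H]1[C@@H](NS(=O)(=O)c2ccc(Cl)cc2)CC[C@@H]1O` differs from compound 2 by carboxy in place of carboxymethyl on a saturated chain carbon, two bonds along the chain from a double-bonded chain carbon with carboxy in place of carboxymethyl on a saturated chain carbon, two bonds along the chain from a double-bonded chain carbon. Among the compounds with values here, no measured pair shows this change, so the expectation is tentative. In this assay the expected change is a 6.3-fold higher number from compound 2 to compound 3 (0.80 log units; beyond the scatter) toward a weaker inhibitor, beyond the scatter. Compound 3 is estimated at 1200 nM with 300 nM to 5000 nM as the expected range.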

Compound 3, half-maximal inhibitory concentration: 1800 nM
Compound 3: middle estimate off by 1.5-fold (0.18 log units), on the low side; the range from low to high includes it.
By their numbers in this assay, from the lowest: compound 2; then compounds 3 and 1 (each within the scatter of the next).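

Within the data shown here, replacing 5-carboxypent-1-en-1-yl with 4-carboxybut-1-en-1-yl gives a 9.5-fold higher number from compound 2 to compound 3 (0.98 log units; beyond the scatter) in this assay, the first direct reading of chain length at this position, and the shortening costs inhibition. With the shorter chain in place, chloro in place of methyl on an aromatic carbon gives a 1.4-fold lower number from compound 1 to compound 3 (0.14 log units; within the scatter), so this aromatic change does not separate the two compounds. Nothing available bears on the reason for the loss from shortening.

Going by these compounds, whether a longer chain than 5-carboxypent-1-en-1-yl gains or loses inhibition remains open. So does the effect of methyl in place of chloro when the chain is 5-carboxypent-1-en-1-yl.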